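From compound 2 to compound 4: an added chloro

The source may hold more compounds than are shown below. What is called first, only, known or untested is meant among the compounds shown, and "the series" means these compounds.

Values in a functional assay on Raji cells (Homo sapiens) for antiproliferative activity, read by MTT assay, with a stated time of 72 h; on this read-out lower numbers stand for stronger inhibition and higher numbers for weaker inhibition:
- compound 1 `CN(Cc1nc(C2CCN(Cc3ccccc3)CC2)no1)c1ncc(/C=C/C(=O)NO)cn1`: 547 nM
- compound 2 `CN(Cc1nc(C2CCN(Cc3ccc(F)cc3)CC2)no1)c1ncc(C(=O)NO)cn1`: 22 nM
- compound 3 `CN(Cc1nc(C2CCN(Cc3ccccc3Cl)CC2)no1)c1ncc(C(=O)NO)cn1`: 48.3 nM

Compound 2 has the lowest number of the three. Compound 4 `CN(Cc1nc(C2CCN(Cc3ccc(F)cc3Cl)CC2)no1)c1ncc(C(=O)NO)cn1` differs from it only in that 4-fluorobenzyl becomes 2-chloro-4-fluorobenzyl, with chloro in place of hydrogen on an aromatic carbon. For the measured compounds named here, one measured step bears on this: a 2.2-fold higher number from compound 2 to compound 3 (0.34 log units; beyond the scatter). That modest step replaces 4-fluorophenyl with 2-chlorophenyl, so the fluoro group is lost there, whereas compound 4 keeps it. Going by the values given here, no measured pair shows the chloro added alone. A small move towards a higher number in this assay is therefore expected, smaller than that step. The expected value for compound 4 is 35 nM, with an estimated range of 14 nM to 85 nM. This estimate means a 1.6-fold higher number from compound 2 to compound 4 (0.20 log units; within the scatter).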

Compound 4, half-maximal inhibitory concentration: 116 nM
Compound 4: middle estimate off by 3.3-fold (0.52 log units), on the low side; measured number above the stated range.
By their numbers in this assay, from the lowest: compound 2; then compound 3; then compound 4; then compound 1.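

In this assay, chloro in place of hydrogen on the 4-fluorobenzyl gives a 5.3-fold higher number from compound 2 to compound 4 (0.72 log units; beyond the scatter) and so raises the number even with the fluoro group kept. The fluoro group brings no gain once chloro is present, as fluoro in place of hydrogen gives a 2.4-fold higher number from compound 3 to compound 4 (0.38 log units; beyond the scatter) on the 2-chlorobenzyl, so in this series both halogens together give a higher number than either alone. Nothing available explains this rise. From the compounds shown here alone, whether methyl or methoxy at this same aromatic carbon would raise the number as chloro does remains open. So does how plain benzyl compares with 4-fluorobenzyl on the core of compound 2.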